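Fluoro in Place of Chloro on Compound 1

The source may hold more compounds than are shown below. What is called first, only, known or untested is meant among the compounds shown, and "the series" means these compounds.

Measured so far:
Compound 1 `C=CCn1c(=O)/c(=C\c2cccc(Cl)c2)[nH]c(=O)/c1=C\c1ccccc1OC` gives 4500 nM in a functional assay on HL-60 cells (Homo sapiens) for cytotoxicity, read by CCK-8 assay, with a stated time of 72 h; a higher number here means a weaker inhibitor, a lower number a stronger inhibitor.
Compound 2 `COc1ccccc1/C=c1/[nH]c(=O)/c(=C\c2ccccc2OC)n(C)c1=O` gives 16200 nM in this assay.
Compound 3 `COc1ccccc1/C=c1/[nH]c(=O)/c(=C\c2cccc(Cl)c2Cl)[nH]c1=O` is reported in this assay as "not active" (no number reported), with no number given.

Of the two compounds with a number, compound 1 has the lower one; compound 2 stands higher by more than the usual scatter. Compound 3 offers no number at all, only a report of no activity. Among the measured compounds shown here, neither compound 2 nor compound 3 differs from compound 1 in a single place, so no measured pair shows the effect of any one change.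

Compound 4 `C=CCn1c(=O)/c(=C\c2cccc(F)c2)[nH]c(=O)/c1=C\c1ccccc1OC` differs from compound 1 in one place only: fluoro in place of chloro on an aromatic carbon. For the measured compounds named here, no measured step tells what this exchange does on this core. With nothing in the data to point strongly either way, the expected step from compound 1 to compound 4 is small, either within the scatter or a little toward a higher number, and is estimated as a 1.3-fold higher number from compound 1 to compound 4 (0.12 log units; within the scatter). Compound 4 is therefore expected to give about 6000 nM in this assay, most likely between 2500 nM and 15000 nM.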

Compound 4, half-maximal inhibitory concentration: 8890 nM
The estimate for compound 4 lay 1.5-fold (0.17 log units) below the measured number; low and high end bracket the measured number.
By their numbers in this assay, from the lowest: compounds 1, 4 and 2 (each within the scatter of the next, the first and the last beyond it).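

In this assay, among the compounds shown here, the exchange of 3-chlorophenyl for 3-fluorophenyl supplies the first single-place comparison on the shared core, with a 2.0-fold higher number from compound 1 to compound 4 (0.30 log units; within the scatter). Where the earlier compounds differed in several places at once and could not isolate any one group, this pair shows that the two halogens cannot be told apart at this position in this read-out, so the measured activity of compound 1 does not depend on chloro as opposed to fluoro. Nothing at hand accounts for this result or shows what lies behind it.

Going by these compounds, what remains open is whether this position stays as undemanding when the halogen gives way to a group of another kind, such as an amine, a carboxylic acid or a longer alkyl chain, or to plain hydrogen, which would show whether any substituent is needed there at all. Also open, on these data alone, is whether fluoro in place of chloro reads the same way on compounds that carry other groups elsewhere on the shared core, as compound 2 and compound 3 do.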